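The source may report more compounds than this note shows. Statements on the series, on what has been measured and on what is new or still open speak of the compounds shown alone.

Measured in an ADME assay on the whole organism (plasma, strain Sprague-Dawley) for pharmacokinetics, with Rattus norvegicus as the target; on this read-out higher numbers stand for fast clearance and lower numbers for slow clearance:
- compound 1 `Nc1nc2c(s1)CCC[C@H]2C(=O)Nc1ccc(C[C@@H]2CC[C@H]([C@H](O)c3ccccc3)N2)cc1`: 185 mL/min/kg
- compound 2 `Nc1nc2c(s1)CC[C@H]2C(=O)Nc1ccc(C[C@@H]2CC[C@H]([C@H](O)c3cccnc3)N2)cc1`: 32 mL/min/kg

Compound 1 stands highest of the two, and compound 2 lies lower by more than the scatter. Compound 3 `O=C(Nc1ccc(C[C@@H]2CC[C@H]([C@H](O)c3ccccc3)N2)cc1)[C@@H]1CCc2scnc21` differs from compound 1 as follows: a group of 8 heavy atoms (6 carbon, 1 nitrogen, 1 sulfur; one five-membered non-aromatic ring of carbon only, one five-membered aromatic ring with 2 hetero atoms) in place of a group of 10 heavy atoms (7 carbon, 2 nitrogen, 1 sulfur; one five-membered aromatic ring with 2 hetero atoms, one six-membered non-aromatic ring of carbon only), on a carbonyl carbon. Among the compounds with values here, no single-change step between measured compounds is available to guide this. A downward move in this assay is expected, of roughly the size of the scatter, since compound 2 at 32 mL/min/kg shows that lower numbers occur in this series. The expected change is a 2.2-fold lower number from compound 1 to compound 3 (0.34 log units; beyond the scatter). For compound 3 the estimate is 85 mL/min/kg, with an expected range of 35 mL/min/kg to 200 mL/min/kg.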

Compound 3, clearance: 80 mL/min/kg
Compound 3: middle estimate off by 1.1-fold (0.03 log units), on the high side; the range from low to high includes it.
By their numbers in this assay, from the lowest: compound 2; then compound 3; then compound 1.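

In this assay, the group with a five-membered non-aromatic ring of carbon only, on a carbonyl carbon whose other neighbour is an amide-type nitrogen, gives a 2.3-fold lower number from compound 1 to compound 3 (0.36 log units; beyond the scatter). This single change therefore moves clearance beyond the scatter, but it alters ring size, heavy-atom count and hydrogen-bond donor count together, so no one of these can be singled out. No measurement at hand bears on the cause of the step.

Still open, on these data alone, is whether the amine alone accounts for any of the step. Also open, as far as these compounds go, is how a methyl group or a fluorine on this group would shift clearance.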